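The source may report more compounds than this note shows. Statements on the series, on what has been measured and on what is new or still open speak of the compounds shown alone.

Measured so far in an assay on isolated protein for inhibition of RAC-alpha serine/threonine-protein kinase (Homo sapiens), tested at 30 uM; on this read-out lower numbers stand for less inhibition and higher numbers for more inhibition at the one concentration tested (going by the name of the read-out):
compound 1 `Cn1cnc2c(Sc3ccc(F)cc3)ncnc21`: 0%
compound 2 `Cn1c(-c2ccccc2)nc2c(Sc3ccc(F)cc3)ncnc21`: 29%
compound 3 `Cn1c(-c2ccc([S+](C)[O-])cc2)nc2c(Sc3ccccc3)ncnc21`: 4%

Compound 3 stands second highest of the three numbers; its nearest neighbour is compound 1, within the scatter, and the furthest is compound 2, beyond it. Compound 4 `Cn1c(-c2ccc([S+](C)[O-])cc2)nc2c(Sc3ccc(F)cc3)ncnc21` is still to be measured. It differs from compound 3 by fluoro in place of hydrogen on an aromatic carbon. Going by the values given here, the only measured step, a number 29 percentage points higher from compound 1 to compound 2 (beyond the scatter), concerns a different change and so does not bear on this one; compound 1 and compound 2 both already carry the fluoro group, so no measured pair isolates its effect. With nothing pointing either way, no step beyond the scatter is expected: a number 2 percentage points higher from compound 3 to compound 4 (within the scatter). For compound 4 the estimate in this assay is 6%, with a range from 0% to 18%.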

Compound 4, a percentage reported as inhibition, at one concentration (the size of the read-out at that concentration, not a potency): 10%
Compound 4: the middle estimate sits 4 percentage points below what was measured; the range from low to high includes it.
By their numbers in this assay, from the lowest: compounds 1, 3 and 4 (each within the scatter of the next); then compound 2.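

Fluoro in place of hydrogen, isolated here for the first time, gives a number 6 percentage points higher from compound 3 to compound 4 (within the scatter) in this assay and so shows no readable effect on the phenylsulfanyl group. Methylsulfinyl in place of hydrogen on the phenyl gives a number 19 percentage points lower from compound 2 to compound 4 (beyond the scatter) and the whole substituted phenyl in place of hydrogen gives a number 10 percentage points higher from compound 1 to compound 4 (within the scatter) so the rise seen with plain phenyl does not carry over to this substituted phenyl. Going by these compounds, whether an amine or a carboxylic acid on that phenyl would keep the higher number stays open. No available evidence accounts for these numbers.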